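The source may hold more compounds than are shown below. What is called first, only, known or untested is meant among the compounds shown, and "the series" means these compounds.

Compound 1 `O=C(Cn1cc(CO)nn1)NCc1ccccc1` is a small amide in which the shared core carries a hydroxymethyl group. Among the compounds with values here, in an ADME assay on cells (spleen, Mus musculus, strain C57BL/6) for inhibition, read by flow cytometry and propidium iodide staining, with a stated time of 24 h, at 37 degrees C (a lower number here means that less compound is needed, a higher number that more compound is needed for the effect), compound 1 gives 490 uM, and this is the only single number recorded in the set. Two close relatives were tested alongside it without a numerical result: compound 2 `O=C(Cn1cc(C(=O)O)nn1)NCc1ccccc1`, which carries an acid on the same core, is reported in this assay as "non-toxic" (no number reported), and compound 3 `COc1cc(OC)cc(-c2cn(CC(=O)NCc3ccccc3)nn2)c1`, which carries a 3,5-dimethoxyphenyl group, is likewise reported in this assay as "non-toxic" (no number reported). Within the data shown here, compound 1 therefore stands alone as the one entry with a measurable concentration, and no step between two measured numbers can be drawn.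

Compound 4 `COc1cccc(-c2cn(CC(=O)NCc3ccccc3)nn2)c1` has not yet been measured in this assay. Relative to compound 1, the change is 3-methoxyphenyl in place of hydroxymethyl on an aromatic carbon. Because compound 3 is reported as "non-toxic" (no number reported), and compound 4 carries a single methoxy on the same kind of aryl group, the expectation is that the step of a 1.4-fold higher number from compound 1 to compound 4 (0.15 log units; within the scatter) is small and, if anything, toward needing more compound, quite possibly beyond what the experiment can resolve. The estimate for compound 4 in this assay is 700 uM, with a likely range from 300 uM to 2000 uM.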

Compound 4, concentration for half-maximal effect: 840 uM
The estimate for compound 4 lay 1.2-fold (0.08 log units) below the measured number; the measured number falls inside the stated range.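

In this assay, within the data shown here, the step between two numbers at this aromatic carbon is a 1.7-fold higher number from compound 1 to compound 4 (0.23 log units; within the scatter), the first such step that can be read in this set. It shows that hydroxymethyl, with its hydrogen-bond donor and no ring, can give way to 3-methoxyphenyl, with six more heavy atoms, a six-membered aromatic ring and no donor, without the two numbers separating beyond the usual scatter. Compound 4 also gives a concentration (840 uM) where compound 3, with its 3,5-dimethoxyphenyl group, is recorded only as ("non-toxic" (no number reported)), and no measurement of any other property accompanies these results that could account for them.

On these data alone, whether an aminomethyl group, a longer chain such as hydroxypropyl, or a plain phenyl on the same aromatic carbon would also stay within the scatter of compound 1 remains open. A single step within the scatter also leaves open whether any group at this place moves the number in this assay by a clear margin, and in which direction.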